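A few compounds are considered here, and "the series" means these few. Any claim that something is new, unique, unknown or untested is made for them only; others in the source may bear on it.

Working notes on the series in a functional assay on A549 cells (Homo sapiens) for antiproliferative activity, read by MTT assay, with a stated time of 48 h; on this read-out lower numbers stand for stronger inhibition and higher numbers for weaker inhibition.

Of the compounds shown here, three have been measured. Compound 1 `CC(=O)OC/C1=C/C[C@](C)(CCC=C(C)C)/C=C/[C@@H](OC(=O)C=C(C)C)[C@](C)(OC(C)=O)/C=C/C1=O` gives 15100 nM. Compound 2 `COC/C1=C/C[C@](C)(CCC=C(C)C)/C=C/[C@@H](OC(=O)C=C(C)C)[C@](C)(O)/C=C/C1=O` gives 3950 nM, the lowest of the two numbers shown, with compound 1 as its nearest neighbour at a gap beyond the usual scatter. Compound 3 `CC(C)=CCC[C@]1(C)/C=C/[C@@H](OC(=O)C=C(C)C)[C@](C)(O)/C=C/[C@H](O)/C(CO)=C\C1` returns only a limit of the assay, > 40000 nM, and no number. The limit line the limit of > 40000 nM in this assay, at which 1 of the 3 values shown sits, covers one of the three values shown. Going by the values given here, no pair among the measured compounds differs in a single place, so no isolated step has been characterised.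

The next compound, compound 4 `CCN(CC)C(=O)/C1=C/C[C@](C)(CCC=C(C)C)/C=C/[C@@H](OC(=O)C=C(C)C)[C@](C)(O)/C=C/C1=O`, is not yet measured. It differs from compound 2 as follows: diethylcarbamoyl in place of methoxymethyl on a double-bonded ring carbon. Among the compounds with values here, with no measured step of this kind to lean on, the expected change from compound 2 to compound 4 is a 1.3-fold higher number from compound 2 to compound 4 (0.10 log units; within the scatter), that is, a step of modest size in either direction, most likely not beyond the scatter. Compound 4 is therefore estimated at 5000 nM, with a plausible range from 1500 nM to 16000 nM.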

Compound 4, half-maximal inhibitory concentration: 11300 nM
Estimate against measurement, compound 4: 2.3-fold (0.35 log units) below, within the range that was stated.
By their numbers in this assay, from the lowest: compound 2; then compounds 4 and 1 (each within the scatter of the next). At a limit, above all of these: compound 3.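

Going by these compounds alone, this is the first single-place change that can be read in this assay: diethylcarbamoyl in place of methoxymethyl on the double-bonded ring carbon gives a 2.9-fold higher number from compound 2 to compound 4 (0.46 log units; beyond the scatter). The change at this position is therefore real but modest, and compound 4 still returns a number, 11300 nM, rather than a limit of the assay. Nothing measured here accounts for the step.

The compounds shown leave open whether the step goes with the carbonyl attached directly to the ring carbon or with the two ethyl chains on the nitrogen. A carboxylic acid, a primary amide or a dimethylcarbamoyl group on the same ring carbon would help to separate these two readings.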